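The compounds below may be only part of what the source reports. "The series", "measured", "known", "first", "only" and "open" are said of these compounds alone.

Working notes on the series, read in a functional assay on HCT-8 cells (Homo sapiens) for cytotoxicity; a higher number here means that more compound is needed for the effect, a lower number that less compound is needed. Compound 1 `COC1=C(C)C(=O)/C(=C(O)/C=C/c2cccc(OC)c2)C(=O)C1(C)C` gives 2.9 ug/mL, compound 2 `COC1=C(C)C(=O)/C(=C(O)/C=C/c2ccc(C)cc2)C(=O)C1(C)C` gives 4.1 ug/mL and compound 3 `COC1=C(C)C(=O)/C(=C(O)/C=C/c2c(C)cccc2C)C(=O)C1(C)C` gives 7.8 ug/mL. Among the measured compounds shown here, only one measured gap sets compound 3 apart: a 2.7-fold higher number from compound 1 to compound 3 (0.43 log units; beyond the scatter), while a 1.9-fold higher number from compound 2 to compound 3 (0.28 log units; within the scatter).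

Compound 4 `C=Cc1ccccc1/C=C/C(O)=C1/C(=O)C(C)=C(OC)C(C)(C)C1=O` carries 2-vinylphenyl in place of 2,6-dimethylphenyl on a double-bonded chain carbon bound to a double-bonded chain carbon.

For the measured compounds named here, the three measured swaps of this phenyl group are the only guide, and all are small. Besides the two above, the third is a 1.4-fold higher number from compound 1 to compound 2 (0.15 log units; within the scatter). Going by the values given here, no measured compound carries a vinyl group, so the data give no direct reading of it. No step beyond the scatter is therefore expected in this assay, and the expected step is a 1.6-fold lower number from compound 3 to compound 4 (0.19 log units; within the scatter). The estimate for compound 4 is 5 ug/mL, with an expected range from 2.5 ug/mL to 10 ug/mL.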

Compound 4, concentration for half-maximal effect: 2.1 ug/mL
Estimate against measurement, compound 4: 2.4-fold (0.38 log units) above; measured number below the stated range.
By their numbers in this assay, from the lowest: compounds 4, 1, 2 and 3 (each within the scatter of the next, the first and the last beyond it).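

Among the compounds shown here, the swap to 2-vinylphenyl on a double-bonded chain carbon bound to a double-bonded chain carbon gives a step in this assay that clears the scatter in the favourable direction (a 3.7-fold lower number from compound 3 to compound 4 (0.57 log units; beyond the scatter)), whereas the one earlier step beyond the scatter ended at compound 3. Against the other two aryl groups, 2-vinylphenyl does not separate (a 2.0-fold lower number from compound 2 to compound 4 (0.29 log units; within the scatter); a 1.4-fold lower number from compound 1 to compound 4 (0.14 log units; within the scatter)), so the new result sets compound 3 further apart from the series rather than opening a new level for compound 4. Nothing measured here bears on what lies behind these differences.

Going by these compounds, it stays open whether the step follows from the vinyl group itself or from the absence of the second methyl group, which a 2-methylphenyl group would help separate. On these data alone, it also stays open how this position would respond to an amine or a carboxylic acid on the phenyl ring.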